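The compounds below may be only part of what the source reports. "The series", "measured", "known", "first", "only" and "open" are said of these compounds alone.

Values in a functional assay on SK-BR-3 cells (Homo sapiens) for antiproliferative activity, read by XTT assay, with a stated time of 72 h; a lower number here means a stronger inhibitor, a higher number a weaker inhibitor:

compound 1, `COc1ccc(-c2cc3ccccc3nc2/C=C/C(=O)c2ccccc2)cc1`: 700 nM
compound 2, `COc1ccc(-c2cc3ccccc3nc2/C=C/C(=O)c2c(OC)cccc2OC)cc1`: 3830 nM
compound 3, `COc1ccc(-c2cc3ccccc3nc2/C=C/C(=O)c2ccc(N)cc2)cc1`: 8560 nM

Compound 2 holds the second highest of the three numbers; nearest is compound 3, reached by a 2.2-fold higher number from compound 2 to compound 3 (0.35 log units; beyond the scatter); furthest is compound 1, from which a 5.5-fold higher number from compound 1 to compound 2 (0.74 log units; beyond the scatter) leads to compound 2.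

Compound 4, `COc1ccc(-c2cc3ccccc3nc2/C=C/C(=O)c2sccc2N)cc1`, differs from compound 2 in one place: 3-aminothiophen-2-yl in place of 2,6-dimethoxyphenyl on a carbonyl carbon. Bearing on this are a 5.5-fold higher number from compound 1 to compound 2 (0.74 log units; beyond the scatter), which puts plain phenyl ahead of 2,6-dimethoxyphenyl, and a 12-fold higher number from compound 1 to compound 3 (1.09 log units; beyond the scatter) together with a 2.2-fold higher number from compound 2 to compound 3 (0.35 log units; beyond the scatter), which show an amino-bearing aryl behind both other aryls. No thiophene has been measured, so the aromatic-ring change itself lacks precedent. The loss of the methoxy groups and the arrival of an amino pull in opposite directions; a modest step to a higher number, or none beyond the scatter, is expected: a 1.3-fold higher number from compound 2 to compound 4 (0.12 log units; within the scatter). Compound 4 is therefore estimated at 5000 nM, within 1500 nM to 16000 nM.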

Compound 4, half-maximal inhibitory concentration: > 10000 nM
Compound 4 ended at the assay's limit (the forecaster's own chance of this, stated with the estimate: 10%); middle value at least 2.0-fold (0.30 log units) away from the limit.
By their numbers in this assay, from the lowest: compound 1; then compound 2; then compound 3. At a limit, above all of these: compound 4.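

In this assay compound 4 gives > 10000 nM, which is a limit of the assay and not a number. A five-membered aromatic ring now stands on the carbonyl carbon, and 3-aminothiophen-2-yl falls behind 2,6-dimethoxyphenyl, with an at least 2.6-fold higher number from compound 2 to compound 4 (0.41 log units; beyond the scatter), and behind phenyl, with an at least 14-fold higher number from compound 1 to compound 4 (1.15 log units; beyond the scatter), while an at least 1.1-fold higher number from compound 3 to compound 4 (0.06 log units; that floor lies within the scatter) leaves 3-aminothiophen-2-yl and 4-aminophenyl unordered, as that floor lies within the scatter.

Open, from the compounds shown here alone, is whether the loss goes with the thiophene ring or with the amino group, which an unsubstituted thiophen-2-yl would help separate. Also open, going by these compounds, is whether a hydroxyl or a fluorine on the phenyl ring would fall behind plain phenyl as amino does.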